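The compounds below may be only part of what the source reports. "The series", "measured", "known", "first", "only" and "open" are said of these compounds alone.

The series shares the core of compound 1 `COc1ccc2c(=O)c(/C=C/C(=O)Nc3cccc(Cl)c3)coc2c1`. In a functional assay (QGY7701 cells, Homo sapiens) for inhibition, read by MTT assay, with a stated time of 48 h (on this read-out lower numbers stand for stronger inhibition and higher numbers for weaker inhibition), compound 1 gives only a limit, > 100000 nM (the limit of > 100000 nM in this assay, at which 1 of the 3 values shown sits). Compound 2 `COc1ccc(CNC(=O)/C=C/c2coc3cc(O)ccc3c2=O)cc1` gives 10000 nM in this assay. Compound 3 `COc1cccc(NC(=O)/C=C/c2coc3cc(OC)ccc3c2=O)c1` gives 39100 nM in this assay, the higher of the two numbers shown, with compound 2 the nearest. Among the measured compounds shown here, the single measured step, an at least 2.5-fold lower number from compound 1 to compound 3 (0.40 log units; beyond the scatter), concerns the substituent on the aryl ring and does not touch the change now at hand. Compound 4 `COc1ccc(CNC(=O)/C=C/c2coc3cc(OC)ccc3c2=O)cc1` differs from compound 3 by 4-methoxybenzyl in place of 3-methoxyphenyl on an amide-type nitrogen. Compound 2 carries the same 4-methoxybenzyl group, and its value stands beside that of compound 3 without a computed step. An expectation for compound 4 in this assay therefore leans on compound 2 with its 10000 nM. Compound 4 is expected near 15000 nM, between 5000 nM and 50000 nM. The step expected is a 2.6-fold lower number from compound 3 to compound 4 (0.42 log units; beyond the scatter).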

Compound 4, half-maximal inhibitory concentration: 15700 nM
Compound 4: middle estimate off by 1.0-fold (0.02 log units), on the low side; the measured number falls inside the stated range.
By their numbers in this assay, from the lowest: compounds 2 and 4 (each within the scatter of the next); then compound 3. At a limit, above all of these: compound 1.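

In this assay, 4-methoxybenzyl on the amide-type nitrogen now has a direct comparison with 3-methoxyphenyl: a 2.5-fold lower number from compound 3 to compound 4 (0.40 log units; beyond the scatter). Methyl in place of hydrogen on an oxygen on an aromatic ring stays within the scatter: a 1.6-fold higher number from compound 2 to compound 4 (0.20 log units; within the scatter). Against 3-chlorophenyl the step is only bounded, an at least 6.3-fold lower number from compound 1 to compound 4 (0.80 log units; beyond the scatter), and compound 1 stands at a limit: the limit of > 100000 nM in this assay, at which 1 of the 4 values shown sits.

The change from 3-methoxyphenyl to 4-methoxybenzyl alters both the methoxy placement and the attachment, and these two compounds cannot separate them. As far as these compounds go, how an amine or a carboxylic acid on the aryl ring, or a longer chain on the amide-type nitrogen, would read remains open.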